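The source may report more compounds than this note shows. Statements on the series, on what has been measured and on what is new or still open speak of the compounds shown alone.

In a functional assay on BV-2 cells (Mus musculus) for inhibition, read by Griess assay, with a stated time of 24 h (a higher number here means a weaker inhibitor, a lower number a stronger inhibitor), compound 1 (`Oc1ccc(Br)cc1-c1ccn(Cc2ccccc2)n1`) gives > 200000 nM, which is a limit of the assay and not a number. Compound 2 (`C=CCc1ccc(O)c(-c2ccn(Cc3ccccc3)n2)c1`) gives 92500 nM, and compound 3 (`CCCc1ccc(O)c(-c2ccn(CCC)n2)c1`) gives 91300 nM, so these two stand within the scatter of each other. Compound 4 (`CCCc1ccc(O)c(-c2ccn(Cc3ccccc3)n2)c1`) follows from compound 3 by phenyl in place of ethyl on a saturated chain carbon bound to an aromatic nitrogen, or propyl to benzyl. Going by the values given here, the only measured single-place step, an at least 2.1-fold lower number from compound 1 to compound 2 (0.33 log units; beyond the scatter), is allyl in place of bromo on an aromatic carbon, so it bears only indirectly. Compound 2 already carries benzyl and gives 92500 nM, so no step beyond the scatter is expected in this assay. The expected step is a 1.2-fold lower number from compound 3 to compound 4 (0.09 log units; within the scatter). For compound 4 the estimated value is 75000 nM, with an expected range of 30000 nM to 170000 nM.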

Compound 4, half-maximal inhibitory concentration: 116000 nM
The estimate for compound 4 lay 1.5-fold (0.19 log units) below the measured number, within the range that was stated.
By their numbers in this assay, from the lowest: compounds 3, 2 and 4 (each within the scatter of the next). At a limit, above all of these: compound 1.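

Phenyl in place of ethyl on a saturated chain carbon bound to an aromatic nitrogen brings a 1.3-fold higher number from compound 3 to compound 4 (0.10 log units; within the scatter), so this assay does not separate propyl from benzyl at this position. Ethyl in place of vinyl on a saturated chain carbon bound to an aromatic carbon brings a 1.3-fold higher number from compound 2 to compound 4 (0.10 log units; within the scatter), so allyl and propyl are not separated either. The exchange of bromo for propyl brings an at least 1.7-fold lower number from compound 1 to compound 4 (0.23 log units; that floor lies within the scatter), a step that rests on a limit of the assay: the limit of > 200000 nM in this assay, at which 1 of the 4 values shown sits.

From the compounds shown here alone, whether an amine or a carboxylic acid on the benzyl group, or a longer chain in place of propyl, moves the number beyond the scatter stays open.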